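Carbamoyl to sulfamoyl on the urea aryl ring

A few compounds are considered here, and "the series" means these few. Any claim that something is new, unique, unknown or untested is made for them only; others in the source may bear on it.

Values in a functional assay on HEL cells (Homo sapiens) for inhibition, read by CCK-8 assay, with a stated time of 72 h; a higher number here means a weaker inhibitor of growth, a lower number a stronger inhibitor of growth:
Compound 1 `CC(=O)c1ccc(NC(=O)N2CCN(c3ccnc(Nc4ccc(N5CCN(C)CC5)cc4)n3)CC2)cc1`: 14100 nM.
Compound 2 `CN1CCN(c2ccc(Nc3nccc(N4CCN(C(=O)Nc5ccc(C(N)=O)cc5)CC4)n3)cc2)CC1`: > 50000 nM, a limit of the assay and not a number.

Compound 2 thus stands only at the limit of > 50000 nM in this assay, at which 1 of the 2 values shown sits, in this assay. The step of an at least 3.5-fold higher number from compound 1 to compound 2 (0.54 log units; beyond the scatter) went in the weakening direction. Compound 3 `CN1CCN(c2ccc(Nc3nccc(N4CCN(C(=O)Nc5ccc(S(N)(=O)=O)cc5)CC4)n3)cc2)CC1` differs from compound 2 by sulfamoyl in place of carbamoyl on an aromatic carbon. Among the measured compounds shown here, no measured step covers sulfamoyl against carbamoyl, so the only anchor is that compound 2 already sits at the limit; a step that the limit leaves unreadable from compound 2 to compound 3 near nothing beyond the scatter is expected. For compound 3 the estimate in this assay is 55000 nM, within 15000 nM to 200000 nM.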

Compound 3, concentration for 50% growth inhibition: > 50000 nM
Compound 3 was reported as a limit; the forecaster's own chance of this, stated with the estimate: 65%; the middle value is on the limit's open side.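

In this assay, acetyl on the aromatic carbon para to a large group now has a second replacement that loses growth inhibition, sulfamoyl, with an at least 3.5-fold higher number from compound 1 to compound 3 (0.54 log units; beyond the scatter). The step between compound 2 and compound 3 cannot be read, since both values are limits of the assay, so carbamoyl and sulfamoyl cannot be ranked. Most of the set now rests on a limit: the limit of > 50000 nM in this assay, at which 2 of the 3 values shown sit.

Going by these compounds, whether any group on this carbon matches or improves on compound 1 at 14100 nM stays open. A nitrile or a methyl ester there would test this.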